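Aryl ether change from compound 2 to compound 3

The source may report more compounds than this note shows. Statements on the series, on what has been measured and on what is new or still open speak of the compounds shown alone.

Among the compounds with values here, compound 2 `c1cc(OC2CCN(c3ccc(-n4ccnc4)nn3)CC2)c2cc[nH]c2c1` gives 162 nM in an assay on microsomes from liver for inhibition of acyl-CoA desaturase 1 (Rattus norvegicus) (on this read-out higher numbers stand for weaker inhibition and lower numbers for stronger inhibition), the highest of the two numbers so far, while compound 1 `c1cn(-c2ccc(N3CCC(Oc4ccc5c(c4)CCC5)CC3)nn2)cn1` gives 62 nM. Within the data shown here, the only measured step, a 2.6-fold higher number from compound 1 to compound 2 (0.42 log units; beyond the scatter), is modest and beyond the scatter. Compound 3 `CCc1cccc(OC2CCN(c3ccc(-n4ccnc4)nn3)CC2)c1` carries 3-ethylphenyl in place of 1H-indol-4-yl on an oxygen on a saturated carbon: the hydrogen-bond donor leaves and a six-membered aromatic ring of carbon only enters, as in compound 1. Among the measured compounds shown here, no step covers this exact change, but the move from compound 1 to compound 2 suggests a modest return toward a lower number. The estimate for compound 3 is 80 nM (range 35 nM to 180 nM), expected as a 2.0-fold lower number from compound 2 to compound 3 (0.31 log units; beyond the scatter).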

Compound 3, half-maximal inhibitory concentration: 38 nM
The estimate for compound 3 lay 2.1-fold (0.32 log units) above the measured number, within the range that was stated.
By their numbers in this assay, from the lowest: compounds 3 and 1 (each within the scatter of the next); then compound 2.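

Against 1H-indol-4-yl, 3-ethylphenyl is clearly favoured on this oxygen in this assay, with a 4.3-fold lower number from compound 2 to compound 3 (0.63 log units; beyond the scatter). With a 1.6-fold lower number from compound 1 to compound 3 (0.21 log units; within the scatter), the ring-opened 3-ethylphenyl and the 2,3-dihydro-1H-inden-5-yl cannot be told apart, so the second fused ring is not required here. Of the three groups, only 1H-indol-4-yl carries a hydrogen-bond donor and it gives the highest number, but one compound cannot separate the donor from the five-membered ring.

No evidence on the cause of these steps is at hand. Open, from the compounds shown here alone, is whether a methoxy group, an amine or a carboxylic acid in place of the ethyl would hold the number.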